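Chain-end variation on the shared core, working notes

The compounds below may be only part of what the source reports. "The series", "measured", "known", "first", "only" and "open" are said of these compounds alone.

Measured so far in a functional assay on the whole organism for antagonist activity, with Mus musculus as the target; on this read-out lower numbers stand for an effect already at smaller amounts and higher numbers for an effect only at larger amounts of compound:
compound 1 `CN(C)CC(=O)NCC(=O)N(C)c1ccc(Cl)cc1C(=O)c1ccccc1Cl` gives 2.6 mg/kg
compound 2 `CCCCC(=O)NCC(=O)N(C)c1ccc(Cl)cc1C(=O)c1ccccc1Cl` gives 1.3 mg/kg
compound 3 `CCN(CC)CC(=O)NCC(=O)N(C)c1ccc(Cl)cc1C(=O)c1ccccc1Cl` gives 2.2 mg/kg

Compound 3 holds the second highest of the three numbers; its distances to the others are a 1.2-fold lower number from compound 1 to compound 3 (0.07 log units; within the scatter) and a 1.7-fold higher number from compound 2 to compound 3 (0.23 log units; within the scatter), both within the scatter. Compound 4 `CC(=O)NCC(=O)N(C)c1ccc(Cl)cc1C(=O)c1ccccc1Cl` is not yet measured. Its change from compound 3 is hydrogen in place of diethylamino on a saturated chain carbon bound to a carbonyl carbon. Within the data shown here, the steps that bear on this position are a 2.0-fold lower number from compound 1 to compound 2 (0.30 log units; within the scatter) and a 1.7-fold higher number from compound 2 to compound 3 (0.23 log units; within the scatter): every variation at this saturated chain carbon so far has stayed within the scatter, whether an amine or a plain chain sits there. No step beyond the scatter is therefore expected for the move to hydrogen, with at most a slight drift toward the lower numbers. For compound 4 the estimate is 1.8 mg/kg, range 0.9 mg/kg to 3.6 mg/kg, corresponding to an expected 1.2-fold lower number from compound 3 to compound 4 (0.09 log units; within the scatter).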

Compound 4, dose for half-maximal effect: 2.3 mg/kg
The estimate for compound 4 lay 1.3-fold (0.11 log units) below the measured number, and the stated range covers the measured number.
By their numbers in this assay, from the lowest: compounds 2, 3, 4 and 1 (each within the scatter of the next).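

Hydrogen on the saturated chain carbon bound to a carbonyl carbon fits with the amine and plain-chain ends in this assay: diethylamino to hydrogen gives (a 1.0-fold higher number from compound 3 to compound 4 (0.02 log units; within the scatter)), dimethylamino to hydrogen gives (a 1.1-fold lower number from compound 1 to compound 4 (0.05 log units; within the scatter)) and propyl to hydrogen gives (a 1.8-fold higher number from compound 2 to compound 4 (0.25 log units; within the scatter)). Even complete loss of the substituent, the largest change here, therefore stays within the scatter, so neither an amine nor propyl is needed at this position to keep the number in this range. No available data explain this flat response.

From the compounds shown here alone, a carboxylic acid, a piperidine or a chain longer than propyl at this carbon remains open. Going by these compounds, whether any group here moves the number beyond the scatter also remains open.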